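The source may hold more compounds than are shown below. What is called first, only, known or untested is meant among the compounds shown, and "the series" means these compounds.

In a functional assay on NCI/ADR-RES cells (Homo sapiens) for inhibition (a lower number here means a stronger inhibitor of growth, a higher number a weaker inhibitor of growth), three compounds sharing one core have been measured, and none of them gives a number. Compound 1 `O=S(=O)(/C=C/c1ccccc1)Cc1ccc(Nc2ncnc3ccccc23)cc1` gives > 100000 nM as a limit and not a number. Compound 2 `O=S(=O)(/C=C/c1ccc(Br)cc1)Cc1ccc(Nc2ncnc3ccccc23)cc1` gives > 100000 nM as a limit too. Compound 3 `CC(C)(C)c1cc(/C=C/S(=O)(=O)Cc2ccc(Nc3ncnc4ccccc34)cc2)cc(C(C)(C)C)c1O` gives > 100000 nM as a limit as well. The whole set shows the limit of > 100000 nM in this assay, at which 3 of the 3 values shown sit, with no readable number among them, so compound 2 has no rank of its own. Among the measured compounds shown here, the one measured step is a step that the two limits leave unreadable from compound 1 to compound 2 and it offers no size to carry forward.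

Compound 4 `O=S(=O)(/C=C/c1ccc(F)cc1F)Cc1ccc(Nc2ncnc3ccccc23)cc1` has not been measured yet. It brings 2,4-difluorophenyl in place of 4-bromophenyl on a double-bonded chain carbon bound to a double-bonded chain carbon as its change, with 2,4-difluorophenyl in place of 4-bromophenyl on a double-bonded chain carbon. No direction can be drawn for this change because compound 2 gives > 100000 nM as a limit and not a number. In this assay the expected result is a number no higher from compound 2 to compound 4 (the limit leaves the size open) with no real change foreseen. Compound 4 is estimated at 100000 nM with an expected range of 30000 nM to 200000 nM and may well report only the limit again.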

Compound 4, concentration for 50% growth inhibition: > 100000 nM
Compound 4 gave a limit, no number; the forecaster's own chance of this, stated with the estimate: 75%; the middle value sits exactly at the limit.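

In this assay compound 4 gives > 100000 nM, a limit and not a number. Among the compounds shown here, no step to compound 4 from compound 1 or compound 2 can be read. The compounds shown leave open what change, if any, would give a readable number, since all share one limit: the limit of > 100000 nM in this assay, at which 4 of the 4 values shown sit.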